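Acetate to free alcohol on a bicyclic terpene core

The source may hold more compounds than are shown below. What is called first, only, known or untested is meant among the compounds shown, and "the series" means these compounds.

Compound 1, `C/C1=C\CCC2=C[C@H](OC2=O)C(C(C)(C)O)CC/C(C)=C/CC1`, gives 5.81 ug/mL in a functional assay on HT-29 cells (Homo sapiens) for cytotoxicity, read by MTT assay, with a stated time of 6 days; on this read-out higher numbers stand for an effect only at larger amounts of compound and lower numbers for an effect already at smaller amounts.
Compound 2, `C=C(C)C1CC[C@@]2(C)CCC[C@@](C)(OC(C)=O)[C@@H]2C1`, gives > 50 ug/mL in this assay, and this is a limit of the assay rather than a measured number.

Of the two measured compounds only compound 1 carries a real value. Among the measured compounds shown here, compound 2 sits at the limit of > 50 ug/mL in this assay, at which 1 of the 2 values shown sits, so where it truly stands is not known, only that no number was reached. For the measured compounds named here, no pair of measured compounds differs in a single place, so no measured step exists to lean on.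

Compound 3, `C=C(C)C1CC[C@@]2(C)CCC[C@@](C)(O)[C@@H]2C1`, differs from compound 2 by hydrogen in place of acetyl on an oxygen on a saturated carbon. Nothing in the two measured compounds shows how such a change plays out in this assay. The shared core of compounds 2 and 3 appears only once among the numbers. The expected change is an at least 1.1-fold lower number from compound 2 to compound 3 (0.04 log units; that floor lies within the scatter), that is, none beyond the usual scatter. Compound 3 is therefore estimated at 45 ug/mL, with a likely range from 15 ug/mL to 120 ug/mL, and it may well return only a limit again.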

Compound 3, concentration for half-maximal effect: > 50 ug/mL
Compound 3: only a limit was reported (the forecaster's own chance of this, stated with the estimate: 55%); middle value at least 1.1-fold (0.04 log units) from the limit.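

Compound 3 gives > 50 ug/mL in this assay, which is a limit of the assay and not a number. No step from compound 2 to compound 3 can be read, because both compounds stand at the same limit: the limit of > 50 ug/mL in this assay, at which 2 of the 3 values shown sit.

As far as these compounds go, whether acetoxy to hydroxy on this shared core changes the effect at all, in either direction, stays open.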